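This account rests on a few compounds, and the source may have more. Where it says the series, first, only, none or still open, it means among the compounds named here.

In an assay on HEK293 cells for positive allosteric modulation of metabotropic glutamate receptor 2 (Rattus norvegicus), read by thallium flux, with a stated time of 2.5 min (on this read-out higher numbers stand for an effect only at larger amounts of compound and lower numbers for an effect already at smaller amounts), compound 3 `Cc1c(OCCCCOCOc2ccc(C(=O)O)cc2)ccc(C(=O)CC2CCCC2)c1O` gives 228 nM, the lowest of the two numbers recorded so far. Compound 1 `Cc1c(OCCCCOc2ccc(C(=O)O)cc2)ccc(C(=O)CC2CCCC2)c1O` gives 824 nM in this assay, and compound 2 `COC(=O)c1ccc(OCCCCOc2ccc(C(=O)CC3CCCC3)c(O)c2C)cc1` has no result there, reported as "not determined" (no result reported). Compound 4 `Cc1c(OCCCCOc2ccc(C(=O)O)cc2F)ccc(C(=O)CC2CCCC2)c1O` has not yet been measured in this assay. It differs from compound 3 in one place: 4-carboxy-2-fluorophenyl in place of (4-carboxyphenoxy)methyl on an oxygen on a saturated carbon. Among the measured compounds shown here, the only measured step that bears on this change is the one from compound 1 to compound 3, a 3.6-fold lower number from compound 1 to compound 3 (0.56 log units; beyond the scatter), where (4-carboxyphenoxy)methyl replaced 4-carboxyphenyl at the same oxygen. For the measured compounds named here, the move to compound 4 undoes that replacement and also brings a fluorine onto the ring, and nothing among the measured compounds shows what such a fluorine does. The reversal alone points back toward the number of compound 1, so the expected step is a 3.1-fold higher number from compound 3 to compound 4 (0.49 log units; beyond the scatter). With the fluorine unaccounted for, the range is kept wide. Compound 4 is estimated at 700 nM in this assay, between 250 nM and 2000 nM.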

Compound 4, half-maximal effective concentration: 639 nM
Compound 4: the middle estimate sits 1.1-fold (0.04 log units) above what was measured; low and high end bracket the measured number.
By their numbers in this assay, from the lowest: compound 3; then compounds 4 and 1 (each within the scatter of the next).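

In this assay, adding fluoro in place of hydrogen on an aromatic carbon gives a 1.3-fold lower number from compound 1 to compound 4 (0.11 log units; within the scatter) and so, on this evidence, does not separate compound 4 from compound 1. Replacing (4-carboxyphenoxy)methyl with 4-carboxy-2-fluorophenyl on the same oxygen gives a 2.8-fold higher number from compound 3 to compound 4 (0.45 log units; beyond the scatter) and shows that this fluoro does not bring the number down to that of compound 3, which keeps the lowest number of the series. Nothing available explains either step.

On these data alone, it remains open whether fluoro would also leave the number unchanged on the ring of compound 3, or whether chloro or methoxy in its place would do the same. Also open, as far as these compounds go, is whether an amide in place of the carboxylic acid would keep these numbers.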